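The source may report more compounds than this note shows. Statements on the series, on what has been measured and on what is new or still open speak of the compounds shown alone.

In a functional assay on KB cells (Homo sapiens) for inhibition (on this read-out lower numbers stand for stronger inhibition and higher numbers for weaker inhibition), compound 1 `COC[C@H]1O[C@@H](n2c(Cl)nc3cc(Cl)c(Cl)cc32)[C@H](OC(C)=O)[C@@H]1OC(C)=O` gives 80000 nM. Compound 2 `CCCCOC[C@H]1O[C@@H](n2c(Cl)nc3cc(Cl)c(Cl)cc32)[C@H](OC(C)=O)[C@@H]1OC(C)=O` is reported only as > 100000 nM, which is a limit of the assay and not a number. Compound 3 `CCOC[C@H]1OC(n2c(Cl)nc3cc(Cl)c(Cl)cc32)[C@H](O)[C@@H]1O` gives 80000 nM, level with compound 1 at the digits shown, so it sits in the same weak range. Compound 4 `CSC[C@H]1OC(n2c(Cl)nc3cc(Cl)c(Cl)cc32)[C@H](O)[C@@H]1O` departs from compound 3 by methylsulfanyl in place of ethoxy on a saturated chain carbon bound to a saturated ring carbon, with methylsulfanyl in place of ethoxy on a saturated chain carbon bound to a saturated ring carbon. Going by the values given here, the only measured step that touches this part of the molecule is an at least 1.2-fold higher number from compound 1 to compound 2 (0.09 log units; that floor lies within the scatter). That step is a floor set by a limit, not a measured size, and it offers no direct measure of the exchange made here. With so little to go on, no step beyond the scatter is expected in this assay, and the expected change is a 1.3-fold lower number from compound 3 to compound 4 (0.12 log units; within the scatter). For compound 4 the estimate is 60000 nM, with an expected range from 25000 nM to 100000 nM.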

Compound 4, half-maximal inhibitory concentration: > 100000 nM
Compound 4 was reported as a limit; the forecaster's own chance of this, stated with the estimate: 30%; middle value at least 1.6-fold (0.22 log units) away from the limit.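

In this assay, compound 4 carries (methylsulfanyl)methyl where compound 3 carries ethoxymethyl, and compound 4 gives > 100000 nM, which is a limit of the assay and not a number. On these data alone, the exchange of ethoxy for methylsulfanyl can therefore be read only as an at least 1.2-fold higher number from compound 3 to compound 4 (0.09 log units; that floor lies within the scatter), so it brings no sign of stronger inhibition, while the true size of the step stays unknown. This floor cannot be told apart from no change because the result stops at the assay's limit: the limit of > 100000 nM in this assay, at which 2 of the 4 values shown sit.

The compounds shown leave open whether any group on this saturated chain carbon can bring inhibition to a value that can be read in full. An amine or a carboxylic acid in place of ethoxy would test this.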